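A few compounds are considered here, and "the series" means these few. Any claim that something is new, unique, unknown or untested is made for them only; others in the source may bear on it.

Measured so far in a physicochemical assay for solubility; a higher number here means a more soluble compound, a lower number a less soluble compound
compound 1 `CNC(=O)c1cc(C(=O)N[C@H]2[C@@H]3COC[C@@H]32)cc2c1OC[C@H]2c1cccc2[nH]ccc12` gives >= 171 ug/mL
compound 2 `CNC(=O)c1cc(C(=O)N[C@H]2[C@@H]3COC[C@@H]32)cc2c1OC[C@H]2c1ccccc1` gives >= 165 ug/mL
compound 3 `CNC(=O)c1cc(C(=O)N[C@H]2[C@@H]3COC[C@@H]32)cc2c1OC[C@H]2c1ccccn1` gives >= 158 ug/mL

Compound 2 stands at >= 165 ug/mL which is a limit of the assay and not a number, and the other two values are limits as well. Compound 4 `CNC(=O)c1cc(C(=O)N[C@H]2C[C@@H]2C)cc2c1OC[C@H]2c1ccccc1` differs from compound 2 only on an amide-type nitrogen, where 2-methylcyclopropyl enters a group of 4 heavy atoms (4 carbon; one three-membered non-aromatic ring of carbon only) in place of a group of 6 heavy atoms (5 carbon, 1 oxygen; one three-membered non-aromatic ring of carbon only, one five-membered non-aromatic ring with 1 hetero atom), on an amide-type nitrogen as the new group. The measured changes are a step that the two limits leave unreadable from compound 1 to compound 2 and a step that the two limits leave unreadable from compound 1 to compound 3 and a step that the two limits leave unreadable from compound 2 to compound 3 and all of them swap the group on a saturated ring carbon. None of them touches the amide-type nitrogen and none has a readable size, so they offer no firm guide to the coming step in this assay in either direction. The expected change is an at least 1.2-fold lower number from compound 2 to compound 4 (0.10 log units; that floor lies within the scatter) as a small fall that may well stay within the usual scatter. Compound 4 is estimated at 130 ug/mL with an expected range from 45 ug/mL to 200 ug/mL and the result may again be only a limit.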

Compound 4, solubility: >= 76 ug/mL
Compound 4 ended at the assay's limit (the forecaster's own chance of this, stated with the estimate: 45%); the middle value is on the limit's open side.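

In this assay compound 4 gives >= 76 ug/mL, which is a limit and not a number. Compound 2 also has only a limit, so no step can be read between compound 2 and compound 4. The compounds shown leave open whether 2-methylcyclopropyl on the amide-type nitrogen changes solubility at all.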